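A Second Methyl on the Aromatic Nitrogen: An Expectation

A few compounds are considered here, and "the series" means these few. Any claim that something is new, unique, unknown or untested is made for them only; others in the source may bear on it.

This account follows a single change inside a small set of compounds tested in a functional assay on HCT-116 cells (Homo sapiens) for inhibition, read by luminescence and resazurin assay, with a stated time of 3 days; on this read-out lower numbers stand for stronger inhibition and higher numbers for weaker inhibition. Compound 1, `CN(C)CCCNc1nc(NCc2ccc(NC(=O)c3ccc(F)cc3)cc2)c2ccccc2n1`, gives 10000 nM in this assay. Compound 2, `CNc1nc(NCc2ccc(NC(=O)c3ccncc3)cc2)c2ccccc2n1`, is the closer relative of the compound to be estimated. For compound 2 this assay reports only a limit, > 20000 nM, and not a number. That is the situation described by the limit of > 20000 nM in this assay, at which 1 of the 2 values shown sits, and it places compound 2 at the weak end of what the two measured values show. Compound 3, `CN(C)c1nc(NCc2ccc(NC(=O)c3ccncc3)cc2)c2ccccc2n1`, has not yet been measured. It differs from compound 2 in one place: methyl in place of hydrogen on a nitrogen on an aromatic ring. Within the data shown here, no step between two measured compounds is available to calibrate this change, so these data give no measured direction for it. Compound 2 already sits at the limit of this assay. The writer expects the step from compound 2 to compound 3 to be a number no higher from compound 2 to compound 3 (the limit leaves the size open), nothing beyond the usual scatter. Compound 3 is therefore estimated at 20000 nM, with a range from 8000 nM to 50000 nM, and a limit rather than a number is judged the likelier outcome.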

Compound 3, half-maximal inhibitory concentration: 15000 nM
For compound 3 the middle estimate is 1.3-fold (0.12 log units) above the measured one; low and high end bracket the measured number.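

In this assay compound 3 gives 15000 nM, a measured number for a compound carrying dimethylamino on this nitrogen on an aromatic ring, and with it the change from methylamino to dimethylamino gains its first step: an at least 1.3-fold lower number from compound 2 to compound 3 (0.12 log units; that floor lies within the scatter). For compound 2 the value > 20000 nM is a limit of the assay and not a number. The step is therefore only a floor, and its true size stays unknown because of that limit: the limit of > 20000 nM in this assay, at which 1 of the 3 values shown sits.

What the compounds shown leave open is how this nitrogen responds to anything other than methyl, for instance an ethyl group or a diethylamino group in place of dimethylamino, which could show whether a step beyond the scatter is possible here at all. Compound 1 offers no answer, since it carries a longer chain at this place and also differs from compound 3 elsewhere, so the effect of that chain, like that of the fluorine-bearing ring of compound 1, cannot be separated in this assay.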